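This account rests on a few compounds, and the source may have more. Where it says the series, first, only, none or still open, it means among the compounds named here.

Measured in a physicochemical assay for solubility; a lower number here means a less soluble compound, a higher number a more soluble compound:
- Compound 1 `CNC(=O)c1cc(C(=O)NC2CC2)cn(CC2CCCCC2)c1=O`: >= 148 ug/mL
- Compound 2 `CNC(=O)c1cc(C(=O)NC2CC2)cn(Cc2cccc([C@@H](C)O)c2)c1=O`: >= 131 ug/mL
- Compound 3 `CNC(=O)c1cc(C(=O)NC2CC2)cn(Cc2ccc3nc[nH]c3c2)c1=O`: >= 163 ug/mL

Compound 3 stands at >= 163 ug/mL, which is a limit and not a number. Compound 1 gives >= 148 ug/mL, also a limit. Compound 2 gives >= 131 ug/mL, again a limit.

Compound 4 `CNC(=O)c1cc(C(=O)NC2CC2)cn(CC2CCOCC2)c1=O` has oxan-4-yl in place of 1H-benzimidazol-6-yl on a saturated chain carbon bound to an aromatic nitrogen. Three measured changes at this place bear on it: a step that the two limits leave unreadable from compound 1 to compound 2, a step that the two limits leave unreadable from compound 1 to compound 3 and a step that the two limits leave unreadable from compound 2 to compound 3. None has a readable size, so no step beyond the scatter is expected in this assay. The expected change is an at least 1.0-fold lower number from compound 3 to compound 4 (0.03 log units; that floor lies within the scatter). For compound 4 the estimate is 150 ug/mL, with an expected range from 105 ug/mL to 190 ug/mL.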

Compound 4, solubility: >= 165 ug/mL
Compound 4: a limit, no number; the forecaster's own chance of this, stated with the estimate: 80%; middle value at least 1.1-fold (0.04 log units) from the limit.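

In this assay, among the compounds shown here, compound 4 gives >= 165 ug/mL, a limit and not a number, so no step to it from compound 1, compound 2 or compound 3 can be read. With all four values given only as limits, the compounds shown leave open whether changing this group alters the read-out at all.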